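A few compounds are considered here, and "the series" means these few. Any claim that something is new, unique, unknown or untested is made for them only; others in the source may bear on it.

In a functional assay on CCRF-CEM cells (Homo sapiens) for cytotoxicity, read by MTT assay, with a stated time of 72 h (on this read-out lower numbers stand for stronger inhibition of growth and higher numbers for weaker inhibition of growth), compound 2 `N#C[Se]c1ccc(NC(=O)Oc2ccc(F)cc2)cc1` gives 12600 nM. Compound 1 `C=CCOC(=O)Nc1ccc([Se]C#N)cc1` gives 9200 nM in this assay; of the two numbers shown, that of compound 2 is the larger, yet its gap to compound 1 lies within the usual scatter, so the two are not separated. Compound 3 `N#C[Se]c1ccc(NC(=O)Oc2ccccc2)cc1` differs from compound 2 by hydrogen in place of fluoro on an aromatic carbon. For the measured compounds named here, no measured pair shows this change; the step is expected to be small, in no set direction and not beyond the scatter. Compound 3 is estimated at 10000 nM, with a range of 4000 nM to 25000 nM, the expected step being a 1.3-fold lower number from compound 2 to compound 3 (0.10 log units; within the scatter).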

Compound 3, concentration for 50% growth inhibition: 22900 nM
Estimate against measurement, compound 3: 2.3-fold (0.36 log units) below, and the stated range covers the measured number.
By their numbers in this assay, from the lowest: compounds 1, 2 and 3 (each within the scatter of the next, the first and the last beyond it).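

In this assay hydrogen in place of fluoro on the aromatic carbon para to a large group gives a 1.8-fold higher number from compound 2 to compound 3 (0.26 log units; within the scatter) and so does not separate the two compounds. Phenyl in place of allyl on the oxygen next to a carbonyl group gives a 2.5-fold higher number from compound 1 to compound 3 (0.40 log units; beyond the scatter) and is the only step here beyond the scatter, though a modest one. No data on hand bear on the cause of either step.

Open, on these data alone, is whether a chloro group or an amine at that aromatic carbon would separate from hydrogen. Also open, as far as these compounds go, is how a longer chain on the oxygen would compare with allyl.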